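This account rests on a few compounds, and the source may have more. Where it says the series, first, only, none or still open, it means among the compounds named here.

Compound 1: `COc1ccc(/C=C(/Sc2ccc(C)cc2)C(=O)c2ccc(Cl)cc2)cc1O` — 1000 nM
Compound 2: `Cc1cc(F)ccc1/C=C(/SCc1ccc(F)cc1)C(=O)c1ccc(Br)cc1` — 10000 nM
Compound 3: `O=C(/C(=C\c1c[nH]c2ccc(Br)cc12)SCc1ccc(F)cc1)c1ccc(Cl)cc1` — 50000 nM

Of the compounds shown here, three sharing a core have been measured in a functional assay on DU-145 cells (Homo sapiens) for inhibition, read by trypan blue exclusion, with a stated time of 96 h; a lower number here means a stronger inhibitor of growth, a higher number a weaker inhibitor of growth. Among the measured compounds shown here, compound 1 stands lowest of the three, with compound 2 giving a higher number and compound 3 a higher number still; both of these gaps lie beyond the scatter, so compound 1 is the strongest inhibitor of growth among the compounds measured so far. Compound 2 and compound 3 are not single-change neighbours of compound 1, so nothing can be said of the cause of their differences.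

Compound 4, `Cc1ccc(S/C(=C/c2cc(C)cc(C)c2)C(=O)c2ccc(Cl)cc2)cc1`, has not yet been measured in this assay. It differs from compound 1 in one place: 3,5-dimethylphenyl in place of 3-hydroxy-4-methoxyphenyl on a double-bonded chain carbon bound to a double-bonded chain carbon. For the measured compounds named here, no measured pair shows this change on its own, so the direction of the step has to be judged from the structures alone. Because compound 1 gives 1000 nM and the change removes the hydrogen-bond donor and acceptors of the 3-hydroxy-4-methoxyphenyl group, compound 4 is expected to be a somewhat weaker inhibitor, a step of a 4.0-fold higher number from compound 1 to compound 4 (0.60 log units; beyond the scatter). The estimate for compound 4 is therefore 4000 nM, with a range from 1000 nM to 20000 nM.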

Compound 4, concentration for 50% growth inhibition: 50000 nM
The estimate for compound 4 lay 13-fold (1.10 log units) below the measured number; the measured number lies above the stated range.
By their numbers in this assay, from the lowest: compound 1; then compound 2; then compounds 3 and 4 (each within the scatter of the next).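

In this assay, among the compounds shown here, 3,5-dimethylphenyl in place of 3-hydroxy-4-methoxyphenyl on a double-bonded chain carbon bound to a double-bonded chain carbon gives a 50-fold higher number from compound 1 to compound 4 (1.70 log units; beyond the scatter), the first step that can be read for a single change. It shows that growth inhibition depends strongly on the group at this place, even though one six-membered aromatic ring of carbon only replaces another and the heavy-atom count barely moves. The group that leaves carries hydrogen-bond donors and acceptors and the group that enters carries none, but no measurement here ties the step to that difference or to any other.

The compounds shown do not separate the hydroxy group from the methoxy group, so 3-hydroxyphenyl and 4-methoxyphenyl at this place remain open. As far as these compounds go, it also remains open how an amine or a carboxylic acid on that ring would compare.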